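Aryl swap on the chain carbon, compound 3 to compound 4

The source may report more compounds than this note shows. Statements on the series, on what has been measured and on what is new or still open speak of the compounds shown alone.

Compound 3 `COc1cccc(/C=C/C(=O)Nc2ccc3ncnc(Nc4cccc(Cl)c4)c3c2)c1` gives 1.05 ug/mL in a functional assay on B16-F10 cells (Mus musculus) for inhibition, read by MTT assay, with a stated time of 48 h (on this read-out higher numbers stand for weaker inhibition and lower numbers for stronger inhibition), the second highest of the three numbers. Compound 2 `O=C(/C=C/c1ccc(Br)cc1)Nc1ccc2ncnc(Nc3cccc(Cl)c3)c2c1` gives 0.75 ug/mL, and the step of a 1.4-fold higher number from compound 2 to compound 3 (0.15 log units; within the scatter) is within the scatter. Compound 1 `O=C(/C=C/c1ccc(Cl)cc1)Nc1ccc2ncnc(Nc3cccc(Cl)c3)c2c1` gives 9.97 ug/mL, with the step of a 9.5-fold lower number from compound 1 to compound 3 (0.98 log units; beyond the scatter) beyond it. Compound 4 `O=C(/C=C/c1cccc2ccccc12)Nc1ccc2ncnc(Nc3cccc(Cl)c3)c2c1` differs from compound 3 by naphthalen-1-yl in place of 3-methoxyphenyl on a double-bonded chain carbon bound to a double-bonded chain carbon. Within the data shown here, the steps that bear on this place are a 9.5-fold lower number from compound 1 to compound 3 (0.98 log units; beyond the scatter) and a 1.4-fold higher number from compound 2 to compound 3 (0.15 log units; within the scatter), one modest and one within the scatter; the step of a 13-fold lower number from compound 1 to compound 2 (1.12 log units; beyond the scatter) sits elsewhere. Changes at this place have so far ranged from none to modest, so for compound 4 a step within the scatter is expected, a 1.1-fold lower number from compound 3 to compound 4 (0.02 log units; within the scatter). The estimate for compound 4 in this assay is 1 ug/mL, between 0.4 ug/mL and 3 ug/mL.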

Compound 4, half-maximal inhibitory concentration: 0.671 ug/mL
Beside the measured number, compound 4's estimate is 1.5-fold (0.17 log units) above it, and the stated range covers the measured number.
By their numbers in this assay, from the lowest: compounds 4, 2 and 3 (each within the scatter of the next); then compound 1.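

Naphthalen-1-yl brings a second six-membered aromatic ring and removes the hydrogen-bond acceptor of 3-methoxyphenyl, yet this assay shows a 1.6-fold lower number from compound 3 to compound 4 (0.19 log units; within the scatter) and a 1.1-fold lower number from compound 2 to compound 4 (0.05 log units; within the scatter), so this place tolerates both changes in the group without a step beyond the scatter. Among these compounds, with a 15-fold lower number from compound 1 to compound 4 (1.17 log units; beyond the scatter), the 4-chlorophenyl of compound 1 remains the one group here set apart from the others. No supporting data on the origin of these steps are available. Open, going by these compounds, is whether an aryl group carrying an amine or a carboxylic acid at this place would stay with compound 2, compound 3 and compound 4 or move toward compound 1.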